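This account rests on a few compounds, and the source may have more. Where it says the series, first, only, none or still open, it means among the compounds named here.

In a functional assay on JC cells (Mus musculus) for inhibition, read by sulforhodamine B assay, with a stated time of 48 h (a higher number here means a weaker inhibitor, a lower number a stronger inhibitor), compound 1 `COc1ccccc1Sc1cn(Cc2ccccc2)c2nc(N)nc(C)c12` gives 11000 nM and compound 2 `COc1ccccc1Cn1cc(Sc2ccccc2OC)c2c(C)nc(N)nc21` gives 9000 nM, two values within the scatter of each other. Compound 3 `COc1ccc(Cn2cc(Sc3ccccc3OC)c3c(C)nc(N)nc32)cc1` differs from compound 2 by one change, (4-methoxyphenyl in place of 2-methoxyphenyl on a saturated chain carbon bound to an aromatic nitrogen), which reads as 2-methoxybenzyl to 4-methoxybenzyl. Going by the values given here, the only measured step that bears on it is a 1.2-fold lower number from compound 1 to compound 2 (0.09 log units; within the scatter), where methoxy stands in place of hydrogen on an aromatic carbon. With that step as the guide, no change beyond the scatter is expected in this assay, in either direction. The estimated step is a 1.1-fold lower number from compound 2 to compound 3 (0.02 log units; within the scatter). Compound 3 is expected at 8500 nM, within an estimated range of 3500 nM to 20000 nM.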

Compound 3, half-maximal inhibitory concentration: 2500 nM
Estimate against measurement, compound 3: 3.4-fold (0.53 log units) above, outside the stated range (below it).
By their numbers in this assay, from the lowest: compound 3; then compounds 2 and 1 (each within the scatter of the next).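

In this assay the place of the methoxy on the benzyl group now matters: 2-methoxybenzyl to 4-methoxybenzyl gives a 3.6-fold lower number from compound 2 to compound 3 (0.56 log units; beyond the scatter) on a saturated chain carbon bound to an aromatic nitrogen. Methoxy in place of hydrogen on an aromatic carbon goes beyond the scatter only as 4-methoxyphenyl, with a 4.4-fold lower number from compound 1 to compound 3 (0.64 log units; beyond the scatter) against a 1.2-fold lower number from compound 1 to compound 2 (0.09 log units; within the scatter) for 2-methoxyphenyl. No evidence given here accounts for this difference. The compounds shown leave open whether another group in place of this methoxy, such as an amine or a carboxylic acid, would give a similar number.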